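The compounds below may be only part of what the source reports. "The series", "measured", "known", "first", "only" and "open" are said of these compounds alone.

Compound 1 `CCCCCC(CCO)n1cnc2c(Cl)ncnc21`, compound 2 `CCCCCCCC(CCO)n1cnc2c(Cl)ncnc21` and compound 3 `CCCCCCCCC(CCO)n1cnc2c(Cl)ncnc21` share one core and differ in the saturated chain attached to it. All three were tested in a functional assay on SW480 cells (Homo sapiens) for antiproliferative activity, read by MTT assay, with a stated time of 48 h; a higher number here means a weaker inhibitor, a lower number a stronger inhibitor. Compound 1 gives > 50000 nM, which is a limit of the assay and not a number. Compound 2 gives 3630 nM. Compound 3 gives 1370 nM, the lowest number of the set.

The next compound, compound 4 `CCCCCCCCCCCC(CCO)n1cnc2c(Cl)ncnc21`, differs from compound 3 by propyl in place of hydrogen on a saturated chain carbon, nine bonds along the chain from an aromatic nitrogen.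

The measured steps that bear on this also extend the chain, and each lowered the number: an at least 13-fold lower number from compound 1 to compound 2 (1.13 log units; beyond the scatter), an at least 36-fold lower number from compound 1 to compound 3 (1.56 log units; beyond the scatter) and a 2.6-fold lower number from compound 2 to compound 3 (0.42 log units; beyond the scatter). The first two are large, but they start from a limit, whereas the last is modest. The chain of compound 4 goes beyond any measured so far, so the trend may not hold. A further drop in this assay is still expected, of modest to large size. The expected step is a 3.0-fold lower number from compound 3 to compound 4 (0.48 log units; beyond the scatter). For compound 4 the estimated value is 450 nM, with an expected range from 90 nM to 3000 nM.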

Compound 4, half-maximal inhibitory concentration: 5290 nM
The estimate for compound 4 lay 12-fold (1.07 log units) below the measured number; measured number above the stated range.
By their numbers in this assay, from the lowest: compound 3; then compounds 2 and 4 (each within the scatter of the next). At a limit, above all of these: compound 1.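

Among the compounds shown here, the gain from lengthening the chain does not continue at this position: propyl in place of hydrogen on a saturated chain carbon, nine bonds along the chain from an aromatic nitrogen, gives a 3.9-fold higher number from compound 3 to compound 4 (0.59 log units; beyond the scatter) in this assay, so the number turns upward here for the first time. The longer chain also cannot be told apart from the shorter one it was compared with, at a 1.5-fold higher number from compound 2 to compound 4 (0.16 log units; within the scatter), which leaves the lowest number of the series at compound 3. The comparison with the shortest chain still reads an at least 9.4-fold lower number from compound 1 to compound 4 (0.97 log units; beyond the scatter), but that step starts from a limit and not a number: the limit of > 50000 nM in this assay, at which 1 of the 4 values shown sits.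

Chains lying in length between those of compound 3 and compound 4 could show where the turn falls, and a longer chain could show whether the number keeps rising. The data do not say what lies behind the turn, or how an amine on the chain would read in this assay.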